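Compound 2 to compound 3: a longer chain

This account rests on a few compounds, and the source may have more. Where it says the series, first, only, none or still open, it means among the compounds named here.

Values measured in a physicochemical assay for lipophilicity (a higher number here means a more lipophilic compound, a lower number a more polar compound), follow.
Compound 1 `Cc1cn(C2CC(N=[N+]=[N-])C(COC(=O)NCCCC(=O)OC(C)(C)C)O2)c(=O)[nH]c1=O` gives 0.88
Compound 2 `Cc1cn(C2CC(N=[N+]=[N-])C(COC(=O)CCCO)O2)c(=O)[nH]c1=O` gives -0.95

Compound 2 stands lowest of the two, with compound 1 higher by a gap beyond the scatter. Compound 3 `Cc1cn(C2CC(N=[N+]=[N-])C(COC(=O)OCCCCCO)O2)c(=O)[nH]c1=O` awaits measurement. It carries (5-hydroxypentyl)oxy in place of 3-hydroxypropyl on a carbonyl carbon, (5-hydroxypentyl)oxy in place of 3-hydroxypropyl on a carbonyl carbon. For the measured compounds named here, no measured pair differs in one place only, and the expectation rests on the structural change alone. Starting from compound 2 at -0.95, an upward step beyond the scatter is expected in this assay. The expected size is a number 0.85 log units higher from compound 2 to compound 3 (beyond the scatter). The estimated value for compound 3 is -0.1, with an expected range of -0.7 to 0.5.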

Compound 3, partition coefficient: -0.45
For compound 3 the middle estimate is 0.35 log units above the measured one; the measured number falls inside the stated range.
By their numbers in this assay, from the lowest: compound 2; then compound 3; then compound 1.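

In this assay, the position on the carbonyl carbon now has its first step between compounds differing in one place: (5-hydroxypentyl)oxy in place of 3-hydroxypropyl gives a number 0.50 log units higher from compound 2 to compound 3 (beyond the scatter), so this position responds to the change. Nothing measured on this series accounts for the step.

The compounds shown leave open how the step divides between the longer carbon chain and the added oxygen on the carbonyl carbon. Also open, as far as these compounds go, is how the number moves with an amine or a carboxylic acid at the chain end in place of the hydroxyl.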